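The compounds below may be only part of what the source reports. "The series", "measured", "known", "first", "only" and "open" are said of these compounds alone.

Among the measured compounds shown here, compound 1 `CCN(CC)CCCC(C)/N=C(/N)NC(=O)c1cccc(F)c1OCc1cc(Br)ccc1OC` is the only compound of this group with a number on record: in a functional assay for antagonist activity at Melanocortin receptor 4 (Homo sapiens), read by cAMP accumulation (on this read-out higher numbers stand for weaker inhibition and lower numbers for stronger inhibition), compound 1 gives 530 nM. Compound 2 `COc1ccc(Br)cc1CCc1c(F)cccc1C(=O)/N=C(\N)NCCC1CCCCC1` stands beside it, and in this assay compound 2 gives "not determined" (no result reported), so there is no single number from which compound 2 can be judged, and nothing can be said about where it lies against compound 1.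

The step to compound 3 `COc1ccc(Br)cc1CCc1c(F)cccc1C(=O)/N=C(\N)NCCCCN1CCCCC1` is a single exchange: 2-(piperidin-1-yl)ethyl in place of cyclohexyl on a saturated chain carbon, two bonds along the chain from an amine nitrogen. For the measured compounds named here, no step between two measured compounds describes such an exchange, so the size of its effect in this assay can only be expected, not read off. Since compound 2 itself carries no number, the expectation has to lean on compound 1, whose chain also ends in a tertiary amine and which gives 530 nM in this assay. Compound 3 is therefore expected to fall in the same broad region, with no direction of change beyond the usual scatter that can be asserted. The estimate for compound 3 in this assay is 400 nM, with a range from 100 nM to 1600 nM.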

Compound 3, half-maximal inhibitory concentration: 70 nM
For compound 3 the middle estimate is 5.7-fold (0.76 log units) above the measured one, outside the stated range (below it).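

Compound 2 has no single number in this assay, and no step can be read from it to compound 3. The compounds shown leave open what the exchange of cyclohexyl for 2-(piperidin-1-yl)ethyl does on its own in this assay. No evidence on record bears on the result for compound 3.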